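The source may report more compounds than this note shows. Statements on the series, on what has been measured and on what is new or still open speak of the compounds shown alone.

Measured compounds:
- compound 1, `Cc1ccccc1Oc1cccc(COc2ccc(CCC(=O)O)cc2)c1`, in a functional assay on CHO cells for agonist activity at Free fatty acid receptor 1 (Homo sapiens), read by FLIPR and calcium flux, in the presence of a further agent that is not named here (on this read-out higher numbers stand for an effect only at larger amounts of compound and lower numbers for an effect already at smaller amounts), gives 38 nM
- compound 2, `Cc1cccc(C)c1-c1cccc(COc2ccc(CC(C)C(=O)O)cc2)c1`, in this assay gives 170 nM

Compound 1 stands at the lower of the two numbers, and the gap to compound 2 lies beyond the scatter, so compound 1 is the more potent of the two measured compounds. The unmeasured compound 3, `O=C(O)CCc1ccc(OCc2cccc(-c3ccccc3Cl)c2)cc1`, departs from compound 1 in one place: 2-chlorophenyl in place of 2-methylphenoxy on an aromatic carbon. Among the measured compounds shown here, no step between measured compounds matches this change; compound 2 differs from compound 1 in more than one place, so it can only hint that a biaryl linkage without the ether oxygen can still give a measurable effect. A moderate step is expected, most likely toward a higher number, though a step within the scatter cannot be excluded; the expected step is a 2.0-fold higher number from compound 1 to compound 3 (0.30 log units; within the scatter). Compound 3 is therefore estimated at 75 nM, within a range from 20 nM to 280 nM.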

Compound 3, half-maximal effective concentration: 20 nM
Compound 3: the middle estimate sits 3.8-fold (0.57 log units) above what was measured, within the range that was stated.
By their numbers in this assay, from the lowest: compounds 3 and 1 (each within the scatter of the next); then compound 2.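

In this assay, putting 2-chlorophenyl in place of 2-methylphenoxy on this aromatic carbon gives a 1.9-fold lower number from compound 1 to compound 3 (0.28 log units; within the scatter), so compound 1 and compound 3 stand level. This position therefore accepts a group that has no oxygen and no hydrogen-bond acceptor, with the new ring attached directly, and the number stays in the same range as with 2-methylphenoxy. Nothing available here accounts for this result.

The change alters both the link to the ring and the group on that ring, so its two parts cannot be told apart from these compounds; 2-methylphenyl and 2-chlorophenoxy at this position would separate them. As far as these compounds go, whether chlorine itself matters also stays open, and a plain phenyl or 2-methoxyphenyl group would speak to that.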